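The source may hold more compounds than are shown below. What is called first, only, known or untested is meant among the compounds shown, and "the series" means these compounds.

Measured compounds:
- compound 1, `CSCC[C@H](N)C(=O)NS(=O)(=O)OC[C@H]1O[C@@H](n2cnc3c(N)ncnc32)[C@H](O)[C@@H]1O`: 500 nM
- compound 2, `N=C(N)NCCC[C@H](N)C(=O)NS(=O)(=O)OC[C@H]1OC[C@@H](n2cnc3c(N)ncnc32)C[C@@H]1O`: 600 nM
- compound 3, `N=C(N)NCCC[C@H](N)C(=O)NS(=O)(=O)OC[C@H]1O[C@@H](n2cnc3c(N)ncnc32)[C@H](O)[C@@H]1O`: 1000 nM

The three compounds share one core and differ only in the side chain on the saturated chain carbon that carries the amine and the carbonyl. In a functional assay on PBMC cells (Homo sapiens) for inhibition (on this read-out lower numbers stand for stronger inhibition and higher numbers for weaker inhibition), compound 3 gives the highest of the three numbers, but its gaps to the other two are within the scatter: compound 2 sits nearest, and compound 1 is furthest. The one step measured at this position, a 2.0-fold higher number from compound 1 to compound 3 (0.30 log units; within the scatter), is itself within the scatter, so the side chain has so far shown no effect that can be separated from repeat-to-repeat variation.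

Compound 4, `CC(C)C[C@H](N)C(=O)NS(=O)(=O)OC[C@H]1O[C@@H](n2cnc3c(N)ncnc32)[C@H](O)[C@@H]1O`, has not yet been measured. It differs from compound 3 as follows:

a group of 3 heavy atoms (3 carbon; no ring) in place of a group of 6 heavy atoms (3 carbon, 3 nitrogen; no ring), on a saturated chain carbon, two bonds along the chain from an amine nitrogen and a carbonyl carbon

For the measured compounds named here, the only step that bears on this change is the one from compound 1 to compound 3, and it was small. The change is therefore expected to give no step beyond the scatter in this assay, and the estimated step is a 1.4-fold lower number from compound 3 to compound 4 (0.15 log units; within the scatter). For compound 4 the expected value in this assay is 700 nM, with a range from 250 nM to 2500 nM.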

Compound 4, half-maximal inhibitory concentration: 1100 nM
Compound 4: the middle estimate sits 1.6-fold (0.20 log units) below what was measured, within the range that was stated.
By their numbers in this assay, from the lowest: compounds 1, 2, 3 and 4 (each within the scatter of the next, the first and the last beyond it).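

At the saturated chain carbon, two bonds along the chain from an amine nitrogen and a carbonyl carbon, isopropyl in place of the group of 6 heavy atoms (3 carbon, 3 nitrogen) gives a 1.1-fold higher number from compound 3 to compound 4 (0.04 log units; within the scatter) in this assay, so a side chain with no nitrogen and no hydrogen-bond donors cannot be told apart from compound 3 here. For the compounds shown here, the position now also gives its first step that stands clear of repeat-to-repeat variation, though a modest one: isopropyl in place of (methylsulfanyl)methyl gives a 2.2-fold higher number from compound 1 to compound 4 (0.34 log units; beyond the scatter) and this is the only such step so far. Nothing available accounts for that step.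

The compounds shown leave open whether a carboxylic acid, a simple amine or a phenyl group on this carbon would give a larger step. They also leave open whether a longer sulfur-bearing chain would stay close to compound 1.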